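The source may report more compounds than this note shows. Statements on the series, on what has been measured and on what is new or still open speak of the compounds shown alone.

Measured compounds:
compound 1 `O=C(O)CC/C=C\CO[C@H]1[C@@H](OCc2ccc(-c3ccccc3CO)cc2)CC[C@@H]1N1CCCCCC1` — 1.59 nM
compound 2 `NC(=O)c1ccccc1-c1ccc(COC2CC[C@H](N3CCCCCC3)[C@H]2OC/C=C\CCC(=O)O)cc1` — 15.9 nM
compound 3 `CC(=O)NCc1ccc(-c2ccc(COC3CC[C@H](N4CCCCCC4)[C@H]3OC/C=C\CCC(=O)O)cc2)cc1` — 2.51 nM

In a functional assay on blood for antagonist activity at thromboxane A2 receptor (Homo sapiens) (on this read-out higher numbers stand for weaker binding and lower numbers for tighter binding), compound 3 gives 2.51 nM, the second highest of the three numbers. Its nearest neighbour is compound 1, which gives 1.59 nM, a gap that lies within the scatter; furthest away is compound 2, which gives 15.9 nM. Among the measured compounds shown here, the one change that has been measured within this set is a 6.3-fold lower number from compound 2 to compound 3 (0.80 log units; beyond the scatter).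

Compound 4 `O=C(O)CC/C=C\CO[C@H]1C(OCc2ccc(-c3ccccc3CO)cc2)CC[C@@H]1N1CCCCCC1` is the compound not yet measured. It differs from compound 3 in one place: 2-(hydroxymethyl)phenyl in place of 4-(acetamidomethyl)phenyl on an aromatic carbon. For the measured compounds named here, the same 2-(hydroxymethyl)phenyl group is already present in compound 1, and the numbers of compound 1 and compound 3 sit within the scatter of each other, so no measured step bears directly on this change and nothing suggests a large move in either direction. The expectation for compound 4 is therefore a step of a 1.4-fold lower number from compound 3 to compound 4 (0.14 log units; within the scatter) in this assay, essentially within the scatter. Compound 4 is expected to give about 1.8 nM, with a likely range from 0.8 nM to 4.5 nM.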

Compound 4, dissociation constant: 3.16 nM
Compound 4: middle estimate off by 1.8-fold (0.24 log units), on the low side; the measured number falls inside the stated range.
By their numbers in this assay, from the lowest: compounds 1, 3 and 4 (each within the scatter of the next); then compound 2.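

In this assay, the exchange on an aromatic carbon para to a large group gives a 1.3-fold higher number from compound 3 to compound 4 (0.10 log units; within the scatter), so this position takes either 4-(acetamidomethyl)phenyl or the smaller 2-(hydroxymethyl)phenyl without a change beyond the scatter. The earlier step replaced the whole 2-carbamoylphenyl group, whereas hydroxymethyl in place of carbamoyl on the same ring alone gives a 5.0-fold lower number from compound 2 to compound 4 (0.70 log units; beyond the scatter), which ties the high number of compound 2 to the carbamoyl group itself. The remaining step, a 2.0-fold higher number from compound 1 to compound 4 (0.30 log units; within the scatter), lies within the scatter and cannot be read as an effect of configuration, because of one fact: the fact that one of compounds 1 and 4 is drawn with a defined configuration and the other without, at the place where they differ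

The compounds shown leave open whether an aminomethyl or a methoxymethyl group on that ring would behave like hydroxymethyl or like carbamoyl. They also leave open how each separate configuration at the undrawn ring carbon of compound 4 would read in this assay.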